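The compounds below may be only part of what the source reports. "The series", "measured", "known", "first", "only" and "open" are said of these compounds alone.

Measured in a functional assay on A549 cells (Homo sapiens) for cytotoxicity, read by MTT assay, with a stated time of 72 h; a lower number here means a stronger inhibitor, a higher number a weaker inhibitor:
compound 1 `CN1CCN(CCCCCCn2c3c(c4ccccc42)C(=O)c2c[n+]([O-])c4ccccc4c2C3=O)CC1` — 330 nM
compound 2 `O=C1c2c[n+]([O-])c3ccccc3c2C(=O)c2c1c1ccccc1n2CCCCN1CCCCC1` — 150 nM
compound 3 `O=C1c2c[n+]([O-])c3ccccc3c2C(=O)c2c1c1ccccc1n2CCCN1CCC(O)CC1` — 350 nM

Compound 1 stands second highest of the three numbers; compound 3 sits within the scatter of it, and compound 2 gives the lowest number, a 2.2-fold lower number from compound 1 to compound 2 (0.34 log units; beyond the scatter). The step of a 1.1-fold higher number from compound 1 to compound 3 (0.03 log units; within the scatter) is within the scatter, and a 2.3-fold higher number from compound 2 to compound 3 (0.37 log units; beyond the scatter) is modest. The whole set spans a narrow band.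

Compound 4 `O=C1c2c[n+]([O-])c3ccccc3c2C(=O)c2c1c1ccccc1n2Cc1cn(C[C@H](O)CO)nn1` differs from compound 1 as follows: 1-(2,3-dihydroxypropyl)-1H-1,2,3-triazol-4-yl in place of 5-(4-methylpiperazin-1-yl)pentyl on a saturated chain carbon bound to an aromatic nitrogen. For the measured compounds named here, none of the measured steps covers this kind of change: each of them swaps one saturated amine-bearing chain for another, whereas here the chain is replaced by an aromatic ring carrying two hydroxyl groups. The measured steps therefore give only the width of the band, not a direction. Going by the values given here, with no precedent in the set, a moderately weaker number is expected for compound 4, a 2.1-fold higher number from compound 1 to compound 4 (0.33 log units; beyond the scatter), with a wide range to reflect the absence of a bearing step. Compound 4 is estimated at 700 nM, between 150 nM and 3500 nM.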

Compound 4, half-maximal inhibitory concentration: 1030 nM
For compound 4 the middle estimate is 1.5-fold (0.17 log units) below the measured one; measured number inside the range.
By their numbers in this assay, from the lowest: compound 2; then compounds 1 and 3 (each within the scatter of the next); then compound 4.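

In this assay, for the compounds shown here, the 1-(2,3-dihydroxypropyl)-1H-1,2,3-triazol-4-yl group on a saturated chain carbon bound to an aromatic nitrogen gives the weakest compound so far, with a 3.1-fold higher number from compound 1 to compound 4 (0.49 log units; beyond the scatter) and a 2.9-fold higher number from compound 3 to compound 4 (0.47 log units; beyond the scatter) and the largest step being a 6.9-fold higher number from compound 2 to compound 4 (0.84 log units; beyond the scatter) in this set. All three steps run the same way, so replacing the chains that end in a six-membered non-aromatic ring with this five-membered aromatic ring gives a higher number against each earlier compound, although compound 4 still reads 1030 nM. No measurement at hand bears on the origin of these steps.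

The compounds shown leave open whether the triazole ring or its two hydroxyl groups carry the step. A triazole bearing a plain propyl chain, or one bearing a piperidine at its chain end, would separate the two.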